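A few compounds are considered here, and "the series" means these few. Any claim that something is new, unique, unknown or untested is made for them only; others in the source may bear on it.

Measured so far in a functional assay on NCI-H23 cells (Homo sapiens) for antiproliferative activity, read by sulforhodamine B assay, with a stated time of 48 h; a lower number here means a stronger inhibitor of growth, a higher number a weaker inhibitor of growth: compound 1 `Cc1nc(SCC(=O)Nc2nc(-c3ccc(Cl)cc3)cs2)n(Nc2ccccc2)c1C` gives 1850 nM; compound 2 `Cc1ccc(Nn2c(SCC(=O)Nc3nc(-c4ccccc4)cs3)nc(C)c2C)cc1` gives 3420 nM.

The two numbers lie within the usual scatter of each other, so compound 1 and compound 2 are not separated by this assay. Compound 3 `COc1ccc(Nn2c(SCC(=O)Nc3nc(-c4ccc(Cl)cc4)cs3)nc(C)c2C)cc1` has not been measured. It differs from compound 1 in one place: methoxy in place of hydrogen on an aromatic carbon. Among the compounds with values here, no measured pair shows this change here, so no direction can be taken from the data. The step of a 1.0-fold lower number from compound 1 to compound 3 (0.01 log units; within the scatter) is expected to stay within the scatter, in either direction. Compound 3 is expected to give about 1800 nM, in the range 700 nM to 4500 nM.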

Compound 3, concentration for 50% growth inhibition: 1530 nM
For compound 3 the middle estimate is 1.2-fold (0.07 log units) above the measured one, within the range that was stated.
By their numbers in this assay, from the lowest: compounds 3, 1 and 2 (each within the scatter of the next, the first and the last beyond it).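

In this assay, methoxy in place of hydrogen on an aromatic carbon, para to a large group, gives a 1.2-fold lower number from compound 1 to compound 3 (0.08 log units; within the scatter). This first one-place pair in the series shows that the anilino group of compound 1 can become (4-methoxyphenyl)amino with no change this assay can separate. No measurement on hand bears on why.

As far as these compounds go, whether an amine or a carboxylic acid at this position would also stay within the scatter remains open. So does the outcome for a longer chain, such as ethoxy, in place of methoxy.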